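A few compounds are considered here, and "the series" means these few. Any claim that something is new, unique, unknown or untested is made for them only; others in the source may bear on it.

Measured compounds in the series:
- compound 1, `CC(C)(Oc1ccccc1)C1OCC(C/C=C\CCC(=O)O)C(c2cccnc2)O1`: 52 nM in an assay for inhibition of Thromboxane-A synthase (Homo sapiens), using microsomes; a higher number here means a weaker inhibitor, a lower number a stronger inhibitor
- compound 2, `Cc1ccc(C#N)c(OC(C)(C)C2OCC(C/C=C\CCC(=O)O)C(c3cccnc3)O2)c1`: 50 nM
- compound 3, `COc1ccccc1OC(C)(C)C1OCC(C/C=C\CCC(=O)O)C(c2cccnc2)O1`: 60 nM

Compound 3 holds the highest of the three numbers, but the gaps are small: a 1.2-fold higher number from compound 1 to compound 3 (0.06 log units; within the scatter) and a 1.2-fold higher number from compound 2 to compound 3 (0.08 log units; within the scatter) both lie within the scatter, so the three compounds cannot be ordered on these data.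

Compound 4, `CSc1ccccc1OC(C)(C)C1OCC(C/C=C\CCC(=O)O)C(c2cccnc2)O1`, is the next step from compound 3. The change is methylsulfanyl in place of methoxy on an aromatic carbon.

Every variation tried so far at the aryl ether end has left this assay essentially unchanged: a 1.0-fold lower number from compound 1 to compound 2 (0.02 log units; within the scatter), a 1.2-fold higher number from compound 1 to compound 3 (0.06 log units; within the scatter) and a 1.2-fold higher number from compound 2 to compound 3 (0.08 log units; within the scatter) are all within the scatter. Among the measured compounds shown here, no measured pair exchanges an oxygen for a sulfur, so there is no direct precedent for that swap. On the evidence of the three steps, the expectation for compound 4 is no movement beyond the scatter, no change at the digits printed from compound 3 to compound 4 (within the scatter). Compound 4 is therefore estimated at 60 nM in this assay, with a likely range from 30 nM to 130 nM.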

Compound 4, half-maximal inhibitory concentration: 36 nM
Compound 4: the middle estimate sits 1.7-fold (0.22 log units) above what was measured; the range from low to high includes it.
By their numbers in this assay, from the lowest: compounds 4, 2, 1 and 3 (each within the scatter of the next).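

In this assay, among the compounds shown here, methylsulfanyl in place of methoxy on an aromatic carbon, ortho to a large group, gives a 1.7-fold lower number from compound 3 to compound 4 (0.22 log units; within the scatter), so the first sulfur-linked group at this place leaves the reading within the scatter. Read against the other two aryl ethers, the same compound gives a 1.4-fold lower number from compound 1 to compound 4 (0.16 log units; within the scatter) and a 1.4-fold lower number from compound 2 to compound 4 (0.14 log units; within the scatter), which extends the lack of any step beyond the scatter to all four compounds. Nothing measured here speaks to the origin of these small steps.

Still open, as far as these compounds go, is whether an amine, methylsulfonyl or ethylsulfanyl on this aromatic carbon would produce a step beyond the scatter. Also open, from the compounds shown here alone, is whether methylsulfanyl would give the same reading on another carbon of this aromatic ring.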